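This account rests on a few compounds, and the source may have more. Where it says the series, first, only, none or still open, it means among the compounds named here.

Compound 1 `CC[C@H](C)[C@H](N)CN(C(=O)[C@@H]1C[C@H]1c1ccc(OC)cc1)c1ccc(-c2ccccc2)cc1` gives > 25000 nM in a functional assay for agonist activity at G protein-coupled receptor 88 (Homo sapiens), read by HTRF and cAMP accumulation (a higher number here means that more compound is needed for the effect, a lower number that less compound is needed), which is a limit of the assay.
Compound 2 `CC[C@H](C)[C@H](N)CN(C(=O)[C@@H]1C[C@H]1C1CCCCC1)c1ccc(-c2ccccc2)cc1` gives > 25000 nM in this assay, again a limit.

Compound 2 therefore stands at the limit, with no number of its own; the step from compound 1 to compound 2 is a step that the two limits leave unreadable from compound 1 to compound 2, as both values sit at the limit of > 25000 nM in this assay, at which 2 of the 2 values shown sit. Compound 3 `CC[C@H](C)[C@H](N)CN(C(=O)[C@@H]1C[C@H]1c1ccc(F)cc1F)c1ccc(-c2ccccc2)cc1` is still to be measured, and differs from compound 2 by 2,4-difluorophenyl in place of cyclohexyl on a saturated ring carbon. Among the measured compounds shown here, the only measured step bearing on this change is the unreadable one from compound 1 to compound 2, which shows that neither a 4-methoxyphenyl nor a cyclohexyl on that saturated ring carbon gave a readable value, so no direction can be taken from it. Compound 3 is expected to give 30000 nM, within 5000 nM to 100000 nM, most probably again as a limit, an expected step that the limit leaves unreadable from compound 2 to compound 3.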

Compound 3, half-maximal effective concentration: 1300 nM
The estimate for compound 3 lay 23-fold (1.36 log units) above the measured number; the measured number lies below the stated range.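

With 2,4-difluorophenyl on the saturated ring carbon, the series gains its first readable number in this assay, and replacing cyclohexyl gives an at least 19-fold lower number from compound 2 to compound 3 (1.28 log units; beyond the scatter). Replacing 4-methoxyphenyl gives an at least 19-fold lower number from compound 1 to compound 3 (1.28 log units; beyond the scatter), so the group at this position can decide whether a readable value appears, and carrying a six-membered aromatic ring is not enough, as compound 1 carries one too. The values of compound 1 and compound 2 are limits, so the step between them cannot be read and the two steps to compound 3 give only a minimum size: the limit of > 25000 nM in this assay, at which 2 of the 3 values shown sit.

From the compounds shown here alone, it remains open whether the readable value needs both fluorines, or whether a plain phenyl or a phenyl with a single fluorine would give one too. Nor do the compounds shown tell whether chlorine in place of fluorine would keep it.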